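Lengthening the nitrile-bearing chain on an aryl ether

The compounds below may be only part of what the source reports. "The series", "measured", "known", "first", "only" and "open" are said of these compounds alone.

Compound 1, `C=CCc1cc(C(C)=O)c(O)cc1OCC#N`: 20%
Compound 2, `C=CCc1cc(C(C)=O)c(O)cc1OCCCC#N`: 47%
Compound 3, `C=CCc1cc(C(C)=O)c(O)cc1OCCCCC#N`: 92%

All three compounds were tested in an assay on isolated protein for inhibition of leukotriene B4 receptor 1 (Homo sapiens), tested at 10 uM; on this read-out higher numbers stand for more inhibition at the one concentration tested (going by the name of the read-out) and lower numbers for less inhibition. Compound 3 stands highest of the three numbers; its nearest neighbour is compound 2, and compound 1 lies furthest below it, both gaps being beyond the scatter. The measured steps all run in one direction: a number 27 percentage points higher from compound 1 to compound 2 (beyond the scatter), a number 45 percentage points higher from compound 2 to compound 3 (beyond the scatter), and across both at once a number 72 percentage points higher from compound 1 to compound 3 (beyond the scatter).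

Compound 4, `C=CCc1cc(C(C)=O)c(O)cc1OCCCCCC#N`, continues the same series. Its difference from compound 3 is cyanomethyl in place of cyano on a saturated chain carbon, four bonds along the chain from an oxygen on an aromatic ring. Each measured step was the same kind of chain extension, and each raised the inhibition, the last one strongly. Compound 3, however, already sits near the top of what this read-out can report, so there is little room for a further rise of the earlier size; a modest further gain, a flat result, or a slight fall are all compatible with the three points in hand.

Compound 4 is therefore expected to remain high, with an estimated 86%, in a range from 55% to 100%. The step of a number 6 percentage points lower from compound 3 to compound 4 (within the scatter) is expected to stay within the scatter.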

Compound 4, a percentage reported as inhibition, at one concentration (the size of the read-out at that concentration, not a potency): 81%
For compound 4 the middle estimate is 5 percentage points above the measured one; measured number inside the range.
By their numbers in this assay, from the lowest: compound 1; then compound 2; then compound 4; then compound 3.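

In this assay, among these compounds, the chain extension stops paying at this position for the first time, with a number 11 percentage points lower from compound 3 to compound 4 (beyond the scatter) as the only step that runs downward, so the steady rise through compound 1, compound 2 and compound 3 does not continue and compound 4 goes against it. Compound 3 thus stands as a peak among the four chain lengths, yet the fall is small beside the earlier gains: the longest chain keeps most of them, with a number 34 percentage points higher from compound 2 to compound 4 (beyond the scatter) and a number 61 percentage points higher from compound 1 to compound 4 (beyond the scatter) still on record. Nothing available here bears on why the number turns down at this length.

The compounds shown leave open whether a longer chain would carry the fall further or level it off, and the downward side of the series rests on this one step alone. They also leave open how much of the result belongs to the nitrile rather than to the chain length, a question that a carboxylic acid or an amine at the chain end, set against compound 3, would address.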